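A Phenyl Swap at the Assay Limit

A few compounds are considered here, and "the series" means these few. Any claim that something is new, unique, unknown or untested is made for them only; others in the source may bear on it.

In a functional assay on HeLa cells (Homo sapiens) for antiproliferative activity, read by sulforhodamine B assay (a lower number here means a stronger inhibitor of growth, a higher number a weaker inhibitor of growth), compound 2 `CCC[C@@H]1O[C@H](COCc2ccccc2)[C@@H](OCc2ccccc2)[C@H](OCc2ccccc2)C1=O` gives > 50000 nM, a limit of the assay and not a number. Compound 1 `CC[C@@H]1O[C@H](COCc2ccccc2)[C@@H](OCc2ccccc2)[C@H](OCc2ccccc2)C1=O` gives > 50000 nM, also a limit. Compound 3 `CCC[C@H]1O[C@H](COCc2ccccc2)[C@@H](OCc2ccccc2)[C@H](OCc2ccccc2)C1=O` gives > 50000 nM, again a limit. The two measured changes are a step that the two limits leave unreadable from compound 1 to compound 2 and a step that the two limits leave unreadable from compound 2 to compound 3. Neither offers a size to carry forward because of the limit of > 50000 nM in this assay, at which 3 of the 3 values shown sit. Compound 4 `O=C1[C@H](Cc2ccccc2)O[C@H](COCc2ccccc2)[C@@H](OCc2ccccc2)[C@@H]1OCc1ccccc1` differs from compound 2 by phenyl in place of ethyl on a saturated chain carbon bound to a saturated ring carbon, which can also be read as propyl to benzyl. With no measured size to lean on, the expected change is a number no higher from compound 2 to compound 4 (the limit leaves the size open), and a readable number, if one appeared, would be expected on the stronger side. Compound 4 is estimated at 50000 nM, with an expected range of 20000 nM to 100000 nM.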

Compound 4, concentration for 50% growth inhibition: > 50000 nM
Compound 4: a limit, no number (the forecaster's own chance of this, stated with the estimate: 75%); the middle value sits exactly at the limit.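

Compound 4 gives > 50000 nM as a limit and not a number. The steps from compound 1 and compound 2 to compound 4 therefore cannot be read: the limit of > 50000 nM in this assay, at which 4 of the 4 values shown sit. The compounds shown leave open whether any change to the shared core would give a readable number.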